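Demethylation of the 3-methoxyphenyl arm in the series

The source may hold more compounds than are shown below. What is called first, only, known or untested is meant among the compounds shown, and "the series" means these compounds.

Measured compounds:
compound 1 `COc1cccc(-c2ccc3ncn(-c4cc(OC)c(OC)c(OC)c4)c3c2)c1`: 1610 nM
compound 2 `COc1cc(-n2cnc3ccc(-c4cccc([N+](=O)[O-])c4)cc32)cc(OC)c1OC`: 4560 nM
compound 3 `COc1cc(-n2cnc3ccc(-c4ccc(F)cc4)cc32)cc(OC)c1OC`: 1770 nM

All three numbers come from a functional assay on MCF7 cells (Homo sapiens) for antiproliferative activity, read by MTT assay, with a stated time of 72 h; on this read-out higher numbers stand for weaker inhibition and lower numbers for stronger inhibition. Compound 1 gives the lowest of the three numbers; compound 3 sits nearest, a 1.1-fold higher number from compound 1 to compound 3 (0.04 log units; within the scatter), and compound 2 furthest, a 2.8-fold higher number from compound 1 to compound 2 (0.45 log units; beyond the scatter). Between the other two the step is a 2.6-fold lower number from compound 2 to compound 3 (0.41 log units; beyond the scatter).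

Compound 4 `COc1cc(-n2cnc3ccc(-c4cccc(O)c4)cc32)cc(OC)c1OC` differs from compound 1 by hydrogen in place of methyl on an oxygen on an aromatic ring. Among the measured compounds shown here, no measured step removes a methyl from an oxygen, so none bears directly on this change. The steps that touch the same aryl arm are the replacement of the whole 3-methoxyphenyl by 4-fluorophenyl, a 1.1-fold higher number from compound 1 to compound 3 (0.04 log units; within the scatter), and nitro in place of methoxy, a 2.8-fold higher number from compound 1 to compound 2 (0.45 log units; beyond the scatter): one within the scatter, one a modest rise in number. That arm therefore tolerates change without large movement in this assay. For compound 4 the step expected in this assay is small, if any, and more likely a rise in number than a fall: a 1.3-fold higher number from compound 1 to compound 4 (0.12 log units; within the scatter). For compound 4 the estimate in this assay is 2100 nM, with a range from 900 nM to 4800 nM.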

Compound 4, half-maximal inhibitory concentration: 350 nM
The estimate for compound 4 lay 6.0-fold (0.78 log units) above the measured number, and the stated range ends above it.
By their numbers in this assay, from the lowest: compound 4; then compounds 1 and 3 (each within the scatter of the next); then compound 2.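

In this assay, among the compounds shown here, hydroxy on this arm is the first change away from 3-methoxyphenyl to bring the number down beyond the scatter, with a 4.6-fold lower number from compound 1 to compound 4 (0.66 log units; beyond the scatter) as the step, so loss of the methyl matters more here than the earlier changes on this arm suggested. For the compounds shown here, the 3-hydroxyphenyl arm also stands apart from the other two arms, with a 5.1-fold lower number from compound 3 to compound 4 (0.70 log units; beyond the scatter) against 4-fluorophenyl and a 13-fold lower number from compound 2 to compound 4 (1.11 log units; beyond the scatter) against 3-nitrophenyl, the last a large step, so this position is more sensitive than the earlier compounds showed. Nothing available explains why the free hydroxy gives the lower number.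

Open, on these data alone, is whether an amine or a carboxylic acid in place of the hydroxy would keep the lower number. Also open, as far as these compounds go, is how an ethoxy group, a longer chain on the same oxygen, would compare with the methoxy of compound 1.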